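Notes on shortening the hydroxyethoxy chain

The compounds below may be only part of what the source reports. "The series", "measured", "known", "first", "only" and "open" are said of these compounds alone.

In a functional assay on RAW264.7 cells (Mus musculus) for inhibition, read by ELISA, with a stated time of 24 h (a lower number here means that less compound is needed, a higher number that more compound is needed for the effect), compound 1 `CC/C=C\C[C@H]1C(=O)C=C[C@H]1CC(=O)OCC` gives 20000 nM, compound 2 `CC/C=C\C[C@H]1C(=O)C=C[C@H]1CC(=O)OCCC` gives 23000 nM and compound 3 `CC/C=C\C[C@H]1C(=O)C=C[C@H]1CC(=O)OCCOCCOCCO` gives 42000 nM. Compound 3 stands clear of only one of the others, and modestly: a 2.1-fold higher number from compound 1 to compound 3 (0.32 log units; beyond the scatter). The other gap stays within the scatter: a 1.8-fold higher number from compound 2 to compound 3 (0.26 log units; within the scatter).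

Compound 4 `CC/C=C\C[C@H]1C(=O)C=C[C@H]1CC(=O)OCCOC` is not yet measured. The change is hydrogen in place of (2-hydroxyethoxy)methyl on a saturated chain carbon bound to an oxygen on a saturated carbon; cut one bond further out, it reads 2-(2-hydroxyethoxy)ethoxy to methoxy. The two steps above bear on it in reverse, since most of the chain they introduce is removed again. The remaining step shows no shift beyond the scatter among the short chains: a 1.2-fold higher number from compound 1 to compound 2 (0.06 log units; within the scatter). A lower number is therefore expected, of about the size of the two reversed steps, though the measured steps are few and small. The expected step is a 1.6-fold lower number from compound 3 to compound 4 (0.21 log units; within the scatter). For compound 4 the estimated value is 26000 nM, with an expected range of 15000 nM to 42000 nM.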

Compound 4, half-maximal effective concentration: 27000 nM
Beside the measured number, compound 4's estimate is 1.0-fold (0.02 log units) below it, within the range that was stated.
By their numbers in this assay, from the lowest: compounds 1, 2, 4 and 3 (each within the scatter of the next, the first and the last beyond it).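

In this assay, the methoxy chain of compound 4 separates from neither short ester: a 1.4-fold higher number from compound 1 to compound 4 (0.13 log units; within the scatter) and a 1.2-fold higher number from compound 2 to compound 4 (0.07 log units; within the scatter), so methoxy in place of hydrogen or methyl at this carbon gives no readable shift. Loss of (2-hydroxyethoxy)methyl, on a saturated chain carbon bound to an oxygen on a saturated carbon, gives a 1.6-fold lower number from compound 3 to compound 4 (0.19 log units; within the scatter), so this cut alone does not clear the scatter. Within the data shown here, the only gap beyond the scatter therefore remains the one between compound 1 and compound 3, with compound 4 inseparable from both.

From the compounds shown here alone, whether an amine or a carboxylic acid at the chain end, or a longer chain capped with methoxy, would move the number beyond the scatter remains open. Nothing shown bears on the cause of these small differences.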